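From Cyclopropyl to tert-Butyl on a Sulfonamide Nitrogen

The source may hold more compounds than are shown below. What is called first, only, known or untested is meant among the compounds shown, and "the series" means these compounds.

Of the compounds shown here, three have so far been measured in a functional assay on BXPC-3 cells (Homo sapiens) for inhibition, read by MTT assay, with a stated time of 7 days; a lower number here means a stronger inhibitor, a higher number a weaker inhibitor. Compound 1 `CCOC(=O)[C@@H]1CCCN(S(=N)(=O)c2ccc(S(=O)(=O)N(CC)CC)cc2)C1` gives 13300 nM. Compound 2 `CCOC(=O)[C@@H]1C[C@H](O)CN(S(=O)(=O)c2ccc(S(=O)(=O)N(CC)CC)cc2)C1` gives 3300 nM. Compound 3 `CC(C)c1noc(N2CCN(C(=O)[C@@H]3CCCN(S(=O)(=O)c4ccc(S(=O)(=O)NC5CC5)cc4)C3)CC2)n1` gives 6700 nM. Among these three numbers compound 3 holds the second highest; its nearest neighbour is compound 1, whose number is higher by a gap within the usual scatter, while compound 2 sits at a lower number beyond the scatter.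

Compound 4 `CC(C)c1noc(N2CCN(C(=O)[C@@H]3CCCN(S(=O)(=O)c4ccc(S(=O)(=O)NC(C)(C)C)cc4)C3)CC2)n1` differs from compound 3 in one place: tert-butyl in place of cyclopropyl on a sulfonamide nitrogen. Going by the values given here, no pair of measured compounds differs in exactly this way, so nothing among the measured compounds shows how such a change moves the number in this assay. In the absence of a guide, the step expected from compound 3 to compound 4 is no change at the digits printed from compound 3 to compound 4 (within the scatter), which is to say no change beyond the scatter in either direction. Compound 4 is therefore estimated to give about 6700 nM in this assay, within a range from 2500 nM to 18000 nM.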

Compound 4, half-maximal inhibitory concentration: 2600 nM
The estimate for compound 4 lay 2.6-fold (0.41 log units) above the measured number, within the range that was stated.
By their numbers in this assay, from the lowest: compounds 4 and 2 (each within the scatter of the next); then compounds 3 and 1 (each within the scatter of the next).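

In this assay, going by these compounds alone, the sulfonamide nitrogen proves to be a place that responds to its substituent: tert-butyl in place of cyclopropyl gives a 2.6-fold lower number from compound 3 to compound 4 (0.41 log units; beyond the scatter) and this is the first pair here that differs in one place. The change replaces a three-membered ring of carbon with an open group of 4 heavy atoms, while the count of hydrogen-bond donors and acceptors stays at 0 in both groups. No measurement offered here accounts for the step.

As far as these compounds go, whether other groups on this nitrogen, such as isopropyl, a longer chain such as n-butyl, or a chain carrying an amine, would move the number further remains open, as does a bare sulfonamide with hydrogen alone in that place. From the compounds shown here alone, it is also open whether the same change would move the number in the same direction on the core of compound 2.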